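From a Bromophenyl Amide to a Fluorophenyl Amide

A few compounds are considered here, and "the series" means these few. Any claim that something is new, unique, unknown or untested is made for them only; others in the source may bear on it.

Three measured compounds share one core and differ only in the aryl group attached to the amide-type nitrogen. Compound 1 `CCOC(=O)C1=Cc2ccccc2OC1(OCc1cn(CC(=O)Nc2cccc(Cl)c2)nn1)C(F)(F)F` carries a 3-chlorophenyl there, and in a functional assay on A549 cells (Homo sapiens) for inhibition, read by MTT assay, with a stated time of 24 h (on this read-out lower numbers stand for stronger inhibition and higher numbers for weaker inhibition), compound 1 gives 12800 nM. Compound 2 `CCOC(=O)C1=Cc2ccccc2OC1(OCc1cn(CC(=O)Nc2ccc(C)cc2)nn1)C(F)(F)F` carries a 4-methylphenyl, and in this assay compound 2 gives 54300 nM, so that a 4.2-fold higher number from compound 1 to compound 2 (0.63 log units; beyond the scatter). Compound 3 `CCOC(=O)C1=Cc2ccccc2OC1(OCc1cn(CC(=O)Nc2ccccc2Br)nn1)C(F)(F)F` carries a 2-bromophenyl. For compound 3 this assay reports only a limit, > 150000 nM, which is not a measured number (the limit of > 150000 nM in this assay, at which 1 of the 3 values shown sits). Both an at least 11-fold higher number from compound 1 to compound 3 (1.06 log units; beyond the scatter) and an at least 2.7-fold higher number from compound 2 to compound 3 (0.44 log units; beyond the scatter) are therefore known only as lower bounds, and compound 3 stands at the weak end of everything measured so far.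

Compound 4 `CCOC(=O)C1=Cc2ccccc2OC1(OCc1cn(CC(=O)Nc2cccc(F)c2)nn1)C(F)(F)F` is the next step: 3-fluorophenyl in place of 2-bromophenyl on an amide-type nitrogen. Its 3-fluorophenyl resembles the 3-chlorophenyl of compound 1 more than the 2-bromophenyl of compound 3, and compound 1 gave the strongest inhibition of the three. Compound 4 is therefore expected to return from the limit to a measurable number, a large step of an at least 6.0-fold lower number from compound 3 to compound 4 (0.77 log units; beyond the scatter) toward stronger inhibition. The estimate for compound 4 in this assay is 25000 nM, with a range from 8000 nM to 90000 nM.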

Compound 4, half-maximal inhibitory concentration: > 150000 nM
Compound 4 ended at the assay's limit; the forecaster's own chance of this, stated with the estimate: 15%; middle value at least 6.0-fold (0.77 log units) from the limit.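

Fluoro in place of chloro on an aromatic carbon gives an at least 11-fold higher number from compound 1 to compound 4 (1.06 log units; beyond the scatter), so on this aryl group the change of one halogen for another is enough to lose the measurable inhibition of compound 1. The 3-fluorophenyl also falls short of the 4-methylphenyl, with an at least 2.7-fold higher number from compound 2 to compound 4 (0.44 log units; beyond the scatter), which leaves the 3-chlorophenyl and the 4-methylphenyl as the only aryl groups shown on the amide-type nitrogen that give a measured number. The reading for compound 4 in this assay is a limit and not a number, and the step from compound 3 cannot be read, because both compounds sit at that same limit: the limit of > 150000 nM in this assay, at which 2 of the 4 values shown sit.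

Going by these compounds, how much inhibition compound 3 and compound 4 have, and whether they differ from each other at all, stays unknown, since neither has a number to compare. Also open, on these data alone, is whether a plain phenyl, or a methoxy group, a nitrile or an amine in place of the fluoro of compound 4, would bring the read-out back to a measurable number in this assay.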